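Terminal amine versus ester on the alkoxy chain

The compounds below may be only part of what the source reports. "The series", "measured", "known", "first", "only" and "open" are said of these compounds alone.

Compound 1 `NCCCCCCOc1ccc2c(=O)c(-c3ccc(O)cc3)coc2c1` gives 100 nM in an assay (Cricetulus griseus) for inhibition of aldehyde dehydrogenase, mitochondrial (Homo sapiens); a higher number here means a weaker inhibitor, a lower number a stronger inhibitor.
Compound 2 `O=C(O)CCCCCCCCCCCCCCCOc1ccc2c(=O)c(-c3ccc(O)cc3)coc2c1` reaches only a limit of this assay, > 9000 nM.

Compound 1 thus holds the only number shown; the remaining value sits at the limit of > 9000 nM in this assay, at which 1 of the 2 values shown sits. Compound 3 `CCOC(=O)CCCCCOc1ccc2c(=O)c(-c3ccc(O)cc3)coc2c1` differs from compound 1 by ethoxycarbonyl in place of aminomethyl on a saturated chain carbon, five bonds along the chain from an oxygen on an aromatic ring. Among the compounds with values here, the one measured step that bears on losing the amine, an at least 90-fold higher number from compound 1 to compound 2 (1.95 log units; beyond the scatter), also lengthens the chain, so it sets a direction rather than a size. Removing the amine is therefore expected to cost potency, roughly a 15-fold higher number from compound 1 to compound 3 (1.18 log units; beyond the scatter). Compound 3 is estimated at 1500 nM, plausibly between 300 nM and 9000 nM.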

Compound 3, half-maximal inhibitory concentration: 280 nM
Compound 3: the middle estimate sits 5.4-fold (0.73 log units) above what was measured; measured number below the stated range.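

In this assay, ethoxycarbonyl in place of aminomethyl, five bonds along the chain from an oxygen on an aromatic ring, gives a 2.8-fold higher number from compound 1 to compound 3 (0.45 log units; beyond the scatter). The amine is therefore not required for a measurable value at this position, so its loss alone does not account for the limit reached by compound 2. Nothing measured here explains the size of this step.

Still open, as far as these compounds go, is whether a carboxylic acid on the chain of compound 3 would keep such a value. Also open, from the compounds shown here alone, is how a longer chain acts when the amine stays in place.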